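Piperidin-1-yl in Place of Carboxymethyl on the Amide Side Chain

A few compounds are considered here, and "the series" means these few. Any claim that something is new, unique, unknown or untested is made for them only; others in the source may bear on it.

Compound 1: `O=C(O)CCC(=O)Nc1ccc(-c2nc3cc(C(F)(F)F)ccc3[nH]2)cc1`; in an ADME assay on MDBK cells (Bos taurus) for cytotoxicity, read by MTT assay, with a stated time of 96 h (a higher number here means that more compound is tolerated, a lower number that less compound is tolerated), compound 1 gives > 100000 nM.
Compound 2: `Fc1ccc(-c2nc3cc(C(F)(F)F)ccc3[nH]2)cc1`; in this assay compound 2 gives 19000 nM.

Compound 1 stands at a limit of this assay, not at a number (the limit of > 100000 nM in this assay, at which 1 of the 2 values shown sits). Among the measured compounds shown here, the one measured step, an at least 5.2-fold lower number from compound 1 to compound 2 (0.72 log units; beyond the scatter), came with fluoro in place of ((2-carboxyethyl)carbonyl)amino on an aromatic carbon. Compound 3, `O=C(CN1CCCCC1)Nc1ccc(-c2nc3cc(C(F)(F)F)ccc3[nH]2)cc1`, differs from compound 1 by piperidin-1-yl in place of carboxymethyl on a saturated chain carbon bound to a carbonyl carbon, keeping the amide but losing the acid. That measured step bears on it only loosely, so a lower number is expected, by about an at least 2.8-fold lower number from compound 1 to compound 3 (0.45 log units; beyond the scatter). Compound 3 is estimated at 35000 nM, within 12000 nM to 100000 nM.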

Compound 3, half-maximal cytotoxic concentration: 6000 nM
Compound 3: the middle estimate sits 5.8-fold (0.77 log units) above what was measured; the measured number lies below the stated range.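

With the amide kept, the change on a saturated chain carbon bound to a carbonyl carbon is enough on its own to take the number in this assay off the limit, with an at least 16-fold lower number from compound 1 to compound 3 (1.22 log units; beyond the scatter) as the step. The earlier step replaced the whole side chain, so a large fall does not require losing the amide. The true size of this step stays a bound, since compound 1 stands at a limit: the limit of > 100000 nM in this assay, at which 1 of the 3 values shown sits.

The compounds shown do not separate the entry of piperidin-1-yl from the loss of carboxymethyl. Dimethylamino or morpholin-4-yl on the same carbon would bear on that question.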